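The source may hold more compounds than are shown below. What is called first, only, known or untested is meant among the compounds shown, and "the series" means these compounds.

Working notes on the series.

Compound 1 `Nc1ncc(Cc2ccccc2I)c(N)n1` carries iodo on an aromatic carbon of the shared core. Within the data shown here, in an assay for inhibition of Dihydrofolate reductase (Gallus gallus) (a higher number here means a weaker inhibitor, a lower number a stronger inhibitor), compound 1 gives 8710 nM, the lowest of the three numbers measured so far. Compound 2 `CS(=O)(=O)Oc1ccccc1Cc1cnc(N)nc1N` gives 22900 nM and compound 3 `C=CCOc1ccccc1Cc1cnc(N)nc1N` gives 21400 nM in this assay. Both steps away from compound 1 run the same way: a 2.6-fold higher number from compound 1 to compound 2 (0.42 log units; beyond the scatter) and a 2.5-fold higher number from compound 1 to compound 3 (0.39 log units; beyond the scatter). Between the two replacements themselves the difference is a 1.1-fold lower number from compound 2 to compound 3 (0.03 log units; within the scatter), so the two groups attached through oxygen are not told apart by this assay.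

Compound 4 `CCOc1ccccc1Cc1cnc(N)nc1N` is the next member. Compared with compound 1, the change is ethoxy in place of iodo on an aromatic carbon.

Among the measured compounds shown here, the steps that bear on this are those from compound 1 to compounds 2 and 3, both modest rises in the number, both beyond the scatter. Compound 4, like compound 2 and compound 3, replaces iodo with a group attached through oxygen, so a rise of similar size is expected rather than no change. The expected step is a 2.3-fold higher number from compound 1 to compound 4 (0.36 log units; beyond the scatter). For compound 4 the estimate in this assay is therefore 20000 nM, with a range from 9000 nM to 45000 nM.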

Compound 4, inhibition constant: 24500 nM
Estimate against measurement, compound 4: 1.2-fold (0.09 log units) below; the range from low to high includes it.
By their numbers in this assay, from the lowest: compound 1; then compounds 3, 2 and 4 (each within the scatter of the next).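

In this assay, among these compounds, ethoxy on this aromatic carbon also sits beyond the scatter from iodo (a 2.8-fold higher number from compound 1 to compound 4 (0.45 log units; beyond the scatter)), so three groups attached through oxygen now stand apart from compound 1, with no compound among the four going against this. Ethoxy is not told apart from allyloxy (a 1.1-fold higher number from compound 3 to compound 4 (0.06 log units; within the scatter)) or from (methylsulfonyl)oxy (a 1.1-fold higher number from compound 2 to compound 4 (0.03 log units; within the scatter)), so in this series neither methyl in place of vinyl at the chain end nor ethyl in place of methylsulfonyl on the oxygen registers in this assay, and the size of the step from iodo is about the same for all three groups. Nothing at hand accounts for the gap between iodo and the groups attached through oxygen.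

With iodo the only group here not attached through oxygen, the compounds shown leave open whether the gap follows the oxygen link or is specific to iodo, which an amine or a methyl group on the same aromatic carbon would help to separate. They also leave open whether the flat response among the oxygen-linked groups would hold for a longer chain such as butoxy, or for a carboxylic acid carried on the oxygen-linked chain.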